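The compounds below may be only part of what the source reports. "The series", "measured", "known", "first", "only" and "open" are said of these compounds alone.

Compound 1 `O=C1O[C@H]([C@@H](O)Cn2cc(-c3cccc(O)c3)nn2)C(OCc2ccccc2)=C1OCc1ccccc1` gives 62700 nM in a functional assay on HepG2 cells (Homo sapiens) for antiproliferative activity, read by MTT assay, with a stated time of 72 h; a higher number here means a weaker inhibitor, a lower number a stronger inhibitor.
Compound 2 `O=C1O[C@H]([C@@H](O)Cn2cc(-c3cc(F)cc(F)c3)nn2)C(OCc2ccccc2)=C1OCc1ccccc1` gives 11600 nM.
Compound 3 `Cc1ccc(-c2cn(C/C=C3\OC(=O)C(OCc4ccccc4)=C3OCc3ccccc3)nn2)cc1` gives > 100000 nM, which is a limit of the assay and not a number.

Of the two numbers recorded, compound 2 stands lowest, and its nearest neighbour is compound 1, with a 5.4-fold lower number from compound 1 to compound 2 (0.73 log units; beyond the scatter). Compound 3 sits at the limit of > 100000 nM in this assay, at which 1 of the 3 values shown sits, so it adds no number to compare against.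

Among the measured compounds shown here, the one change made on compound 2 to give compound 4 `O=C1O[C@H]([C@@H](O)Cn2cc(CNS(=O)(=O)c3ccc(F)cc3)nn2)C(OCc2ccccc2)=C1OCc1ccccc1` is (((4-fluorophenyl)sulfonyl)amino)methyl in place of 3,5-difluorophenyl on an aromatic carbon. For the measured compounds named here, the single measured step, a 5.4-fold lower number from compound 1 to compound 2 (0.73 log units; beyond the scatter), kept the six-membered ring in place and only altered what sat on it, yet it shifted the result by a modest amount. Going by the values given here, the move to compound 4 is larger in kind: the 3,5-difluorophenyl leaves entirely and the (((4-fluorophenyl)sulfonyl)amino)methyl enters, and no measured pair shows such an exchange. A step of roughly the size seen in a 5.4-fold lower number from compound 1 to compound 2 (0.73 log units; beyond the scatter) is therefore expected, most likely toward a higher number, since the only improvement recorded came from the difluorinated six-membered ring that compound 4 no longer carries. The expected step is a 1.9-fold higher number from compound 2 to compound 4 (0.28 log units; within the scatter). Compound 4 is estimated at 22000 nM, within a range from 5000 nM to 90000 nM.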

Compound 4, half-maximal inhibitory concentration: 18300 nM
Compound 4: the middle estimate sits 1.2-fold (0.08 log units) above what was measured; the range from low to high includes it.
By their numbers in this assay, from the lowest: compounds 2 and 4 (each within the scatter of the next); then compound 1. At a limit, above all of these: compound 3.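

At the aromatic carbon of the five-membered ring with 3 nitrogen, a very different group can take the place of the 3,5-difluorophenyl without a measurable loss, with a 1.6-fold higher number from compound 2 to compound 4 (0.20 log units; within the scatter) in this assay. Until now, only six-membered aromatic rings attached directly to this carbon had a measured value, whereas the (((4-fluorophenyl)sulfonyl)amino)methyl of compound 4 brings a hydrogen-bond donor and 2 hydrogen-bond acceptors, so a direct ring attachment is not required for this level of activity. The group in compound 4 also compares well with the 3-hydroxyphenyl, with a 3.4-fold lower number from compound 1 to compound 4 (0.53 log units; beyond the scatter), although nothing given here explains why this exchange is tolerated or why compound 1 gives a higher number.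

On these data alone, it remains open which part of the new group matters: the 4-fluoro substituent, the sulfonyl or the methylene link. An amide or a simple amine at this position would help to separate these parts, and a carboxylic acid would show whether this carbon also accepts a charged group.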